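Cytotoxicity on MDCK cells: pyrazine to pyrimidine swap

The source may report more compounds than this note shows. Statements on the series, on what has been measured and on what is new or still open speak of the compounds shown alone.

The series rests on a shared bicyclic amine core bearing a heteroaryl-methyl group. Compound 1 `Cc1ccc(CN[C@@H]2C[C@H]3C[C@@H]([C@H]2C)C3(C)C)s1` carries 5-methylthiophen-2-yl; in an ADME assay on MDCK cells (Canis lupus familiaris) for cytotoxicity, read by microscopy, with a stated time of 48 h (a higher number here means that more compound is tolerated, a lower number that less compound is tolerated), compound 1 gives 780 nM. Compound 2 `C[C@H]1[C@H](NCc2cnccn2)C[C@H]2C[C@@H]1C2(C)C` carries pyrazin-2-yl instead. In this assay compound 2 reaches only > 100000 nM, which is a limit of the assay and not a number, as recorded by the limit of > 100000 nM in this assay, at which 1 of the 2 values shown sits. The step of an at least 120-fold higher number from compound 1 to compound 2 (2.10 log units; beyond the scatter) shows that the pyrazine analogue is tolerated far more than the thiophene analogue.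

Compound 3 `C[C@H]1[C@H](NCc2cncnc2)C[C@H]2C[C@@H]1C2(C)C` differs from compound 2 by pyrimidin-5-yl in place of pyrazin-2-yl on a saturated chain carbon bound to an amine nitrogen. Going by the values given here, only the step from compound 1 to compound 2 is available for comparison, and it exchanges a thiophene for a nitrogen-containing six-membered ring; the change to compound 3 keeps a six-membered aromatic ring with two nitrogen atoms, so that large step gives no direct guide. Among the compounds with values here, with no closer precedent, the expected step of a number no higher from compound 2 to compound 3 (the limit leaves the size open) is none beyond the scatter. For compound 3 the minimum cytotoxic concentration in this assay is estimated at 100000 nM, in the range 30000 nM to 300000 nM, most likely again reported as a limit.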

Compound 3, minimum cytotoxic concentration: > 100000 nM
Compound 3 was reported as a limit; the forecaster's own chance of this, stated with the estimate: 70%; the middle value sits exactly at the limit.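

In this assay compound 3 gives > 100000 nM, which is a limit of the assay and not a number. The step of an at least 120-fold higher number from compound 1 to compound 3 (2.10 log units; beyond the scatter) shows that the large separation from 5-methylthiophen-2-yl is not confined to pyrazin-2-yl: on a saturated chain carbon bound to an amine nitrogen, pyrimidin-5-yl, a second six-membered aromatic ring with 2 hetero atoms, stands just as clear of compound 1. The step between compound 2 and compound 3 cannot be read, because the two compounds share the same limit: the limit of > 100000 nM in this assay, at which 2 of the 3 values shown sit.

The compounds shown leave open whether pyrazin-2-yl and pyrimidin-5-yl differ at all in this assay. They also leave open where a phenyl group, a pyridin-3-yl group or a thiophen-2-yl group without the methyl group would fall in this assay relative to compound 1 and the two limits, and so whether the large step follows the loss of the thiophene ring, of the methyl group or of both.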